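Swapping the aryl arm of compound 2 for a pyrazolylamino group

The compounds below may be only part of what the source reports. "The series", "measured", "known", "first", "only" and "open" are said of these compounds alone.

The shared core of compound 2 `Cc1nc(CO)ccc1-c1cnc(NCc2c(F)ccc3c2CCO3)c2cn[nH]c(=O)c12` also carries compound 4 `CN(c1ccn(C)n1)c1cnc(NCc2c(F)ccc3c2CCO3)c2cn[nH]c(=O)c12`, which has not yet been tested. In an ADME assay on microsomes from liver (Homo sapiens) for metabolic stability, read by LC-MS, using NADPH, with stated times of 5 min and 30 min, tested at 1 uM (on this read-out higher numbers stand for fast clearance and lower numbers for slow clearance), compound 2 gives 11 mL.min-1.g-1, the lowest of the two numbers shown. Its nearest neighbour is compound 1 `O=C(Nc1ccccc1)c1cnc(NCc2c(F)ccc3c2CCO3)n2cnnc12`, which in this assay gives 14 mL.min-1.g-1, a gap within the scatter. Compound 3 `O=C1CCCN1c1cnc(NCc2c(F)ccc3c2CCO3)n2cnnc12` is reported only as a limit, < 3 mL.min-1.g-1, in this assay (the limit of < 3 mL.min-1.g-1 in this assay, at which 1 of the 3 values shown sits).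

Going by the values given here, the one measured step, an at least 4.6-fold lower number from compound 1 to compound 3 (0.66 log units; beyond the scatter), concerns a different core and a different exchange, and so does not speak directly to the change from compound 2 to compound 4, which is methyl(1-methyl-1H-pyrazol-3-yl)amino in place of 6-(hydroxymethyl)-2-methylpyridin-3-yl on an aromatic carbon. Among the compounds with values here, no measured pair shows this kind of exchange, so no step beyond the scatter is expected in either direction, and compound 4 is expected to give 12 mL.min-1.g-1 in this assay, within 5 mL.min-1.g-1 to 30 mL.min-1.g-1. This amounts to an expected step of a 1.1-fold higher number from compound 2 to compound 4 (0.04 log units; within the scatter).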

Compound 4, intrinsic clearance in microsomes: 62 mL.min-1.g-1
Compound 4: middle estimate off by 5.2-fold (0.71 log units), on the low side; measured number outside the range, above it.
By their numbers in this assay, from the lowest: compounds 2 and 1 (each within the scatter of the next); then compound 4. At a limit, below all of these: compound 3.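

The earlier compounds shown here held no measured pair at this position, and this exchange now supplies one: in this assay, methyl(1-methyl-1H-pyrazol-3-yl)amino in place of 6-(hydroxymethyl)-2-methylpyridin-3-yl gives a 5.6-fold higher number from compound 2 to compound 4 (0.75 log units; beyond the scatter) on the shared core. The group on this aromatic carbon can therefore move clearance in microsomes, and of the two groups the pyridinyl arm stands with the lower number. This rests on a single pair on one core, and nothing measured here bears on why the number rises.

The compounds shown leave open whether the rise follows the pyrazole ring or the methylated amino link, which an unmethylated amino link would help to separate. They also leave open how a plain phenyl ring or a morpholine would read on this carbon in this assay.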